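A few compounds are considered here, and "the series" means these few. Any claim that something is new, unique, unknown or untested is made for them only; others in the source may bear on it.

Working notes on the series. Two compounds have numbers in a physicochemical assay, with a stated time of 6 min; on this read-out higher numbers stand for weaker inhibition and lower numbers for stronger inhibition. Compound 1, `COc1ccc(NC(=O)Nc2nc(-c3cc4cc([N+](=O)[O-])ccc4o3)cs2)cc1`, gives 121000 nM in this assay. Compound 2, `O=C(Nc1ccc(F)cc1)Nc1nc(-c2cc3cc(Br)ccc3o2)cs1`, is reported only as a limit in this assay, > 200000 nM, and carries no number of its own; it sits at the limit of > 200000 nM in this assay, at which 1 of the 2 values shown sits. Compound 2 therefore stands as the weaker-looking of the two shown, though with only a limit its true place cannot be fixed.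

Compound 3, `COc1cccc(NC(=O)Nc2nc(-c3cc4cc(Br)ccc4o3)cs2)c1`, has not yet been measured in this assay. It differs from compound 2 by 3-methoxyphenyl in place of 4-fluorophenyl on an amide-type nitrogen. Within the data shown here, no step between measured compounds is recorded for this change, so its effect is unknown. Compound 2 is known only as a limit in this assay. Compound 1 gives 121000 nM in this assay. On that basis a step from compound 2 to compound 3 of about an at least 1.3-fold lower number from compound 2 to compound 3 (0.12 log units; that floor lies within the scatter) is expected, possibly none beyond the scatter. Compound 3 is estimated at 150000 nM, in the range 50000 nM to 400000 nM, with a fair chance that this assay again returns only a limit.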

Compound 3, half-maximal inhibitory concentration: > 200000 nM
Compound 3 was reported as a limit; the forecaster's own chance of this, stated with the estimate: 45%; middle value at least 1.3-fold (0.12 log units) from the limit.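

Compound 2 and compound 3 both stand only as limits in this assay, and no step can be read between them for 3-methoxyphenyl in place of 4-fluorophenyl: the limit of > 200000 nM in this assay, at which 2 of the 3 values shown sit. The compounds shown leave open the true values of both and whether this change has any effect.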